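A few compounds are considered here, and "the series" means these few. Any claim that something is new, unique, unknown or untested is made for them only; others in the source may bear on it.

Measured in a physicochemical assay for lipophilicity; on this read-out lower numbers stand for lower lipophilicity and higher numbers for higher lipophilicity:
- compound 1 `CN1CCN(c2cc(C(F)(F)F)ccc2[C@H]2CCOc3cc(S(=O)(=O)Nc4nccs4)ccc32)CC1`: 2.1
- compound 2 `O=S(=O)(Nc1nccs1)c1ccc2c(c1)OCC[C@@H]2c1ccc(C(F)(F)F)cc1-c1ccc(F)cc1`: 4.5
- compound 3 `O=S(=O)(Nc1nccs1)c1ccc2c(c1)OCC[C@@H]2c1ccc(C(F)(F)F)cc1N1CCNCC1`: 1.4

Compound 3 is the lowest of the three in this assay, at 1.4. Compound 1 sits nearest to it and compound 2 furthest away.

The next structure is compound 4 `O=S(=O)(Nc1nccs1)c1ccc2c(c1)OCC[C@@H]2c1ccc(C(F)(F)F)cc1-c1nccs1`, not yet measured. The change is 1,3-thiazol-2-yl in place of piperazin-1-yl on an aromatic carbon, ortho to a large group and meta to a trifluoromethyl group.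

Going by the values given here, two measured steps bear most directly on this position. The closest is a number 3.10 log units lower from compound 2 to compound 3 (beyond the scatter), where piperazin-1-yl replaces 4-fluorophenyl. The second is a number 2.40 log units higher from compound 1 to compound 2 (beyond the scatter), where 4-fluorophenyl replaces 4-methylpiperazin-1-yl. The smaller step of a number 0.70 log units lower from compound 1 to compound 3 (beyond the scatter) involves only the methyl on the ring nitrogen and says little about an aromatic replacement.

Among the compounds with values here, the entering group is an aromatic ring, as 4-fluorophenyl is, but no measured compound carries it at this position. A large upward move is therefore expected, probably falling somewhat short of the gap between compound 3 and compound 2. The expected step is a number 2.10 log units higher from compound 3 to compound 4 (beyond the scatter).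

For compound 4 the estimated value is 3.5, with an expected range from 2.9 to 4.1.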

Compound 4, distribution coefficient: 3.3
Beside the measured number, compound 4's estimate is 0.20 log units above it, and the stated range covers the measured number.
By their numbers in this assay, from the lowest: compound 3; then compound 1; then compound 4; then compound 2.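

In this assay, placing 1,3-thiazol-2-yl on this aromatic carbon, ortho to a large group and meta to a trifluoromethyl group, gives a number 1.90 log units higher from compound 3 to compound 4 (beyond the scatter) and so shows that a second aromatic ring also sits well clear of the piperazin-1-yl level. The two aromatic groups do not read alike, with a number 1.20 log units lower from compound 2 to compound 4 (beyond the scatter) when 1,3-thiazol-2-yl takes the place of 4-fluorophenyl, so the size of the move at this position depends on which aromatic ring enters and not only on the ring being aromatic. Against the N-methyl amine the change still gives a number 1.20 log units higher from compound 1 to compound 4 (beyond the scatter) and thereby places the thiazole compound between the amine-bearing compounds and the 4-fluorophenyl compound, but no supporting data are available to account for this order.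

From the compounds shown here alone, it remains open whether the gap between the two aromatic groups goes with ring size, with the hetero atoms of the ring or with the fluorine of the 4-fluorophenyl group. A plain phenyl ring or a pyridin-2-yl ring on this carbon would begin to separate those parts, and a morpholin-4-yl ring would test the non-aromatic side of the series.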